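This account rests on a few compounds, and the source may have more. Where it says the series, first, only, none or still open, it means among the compounds named here.

Measured so far:
- compound 1, `CCOC(=O)[C@@]1(Cc2ccccc2)S[C@@H](F)C(C)(C)C1=O.CCOC(=O)[C@@]1(Cc2ccccc2)S[C@H](F)C(C)(C)C1=O`: 0.2 ug/mL
- compound 2, `CCOC(=O)[C@@]1(Cc2ccccc2)S[C@H](F)C(C)(C)C1=O`: 0.21 ug/mL

In an assay on isolated protein for inhibition of Group IID secretory phospholipase A2 (Homo sapiens) (a higher number here means a weaker inhibitor, a lower number a stronger inhibitor), compound 1 gives 0.2 ug/mL and compound 2 gives 0.21 ug/mL; compound 2 holds the higher of the two numbers, but the gap to compound 1 is within the scatter, so the two read as the same. Compound 1 is drawn as the pair of both configurations at the fluorinated ring carbon; compound 2 is one of them.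

Compound 3, `CCOC(=O)[C@@]1(Cc2ccccc2)S[C@@H](F)C(C)(C)C1=O`, is the other one: the two compounds have the same atoms and bonds and differ only in configuration as drawn: 1 of 2 stereo elements differ; a stereocentre at a saturated ring carbon is drawn S in compound 2 and R in compound 3. Among the compounds with values here, no step between measured compounds addresses this change directly. Since compound 1, which contains both forms, gives 0.2 ug/mL and compound 2 gives 0.21 ug/mL, the remaining form is not expected to depart far from them; the step is expected to be a 1.1-fold lower number from compound 2 to compound 3 (0.02 log units; within the scatter), nothing beyond the scatter in either direction. For compound 3 the expected value in this assay is 0.2 ug/mL, within 0.08 ug/mL to 0.6 ug/mL.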

Compound 3, half-maximal inhibitory concentration: 1.27 ug/mL
Compound 3: the middle estimate sits 6.4-fold (0.80 log units) below what was measured, and the stated range ends below it.
By their numbers in this assay, from the lowest: compounds 1 and 2 (each within the scatter of the next); then compound 3.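

In this assay the configuration at the saturated ring carbon carrying fluorine is not neutral: going from S to R gives a 6.0-fold higher number from compound 2 to compound 3 (0.78 log units; beyond the scatter). The step can be assigned to this one stereocentre and to nothing else in the structure on one ground: the fact that compounds 2 and 3 differ only in the configuration as drawn. Compound 1, which holds both forms, gives 0.2 ug/mL, and this reads the same as compound 2 at 0.21 ug/mL, so the pair sits with the S form and apart from compound 3 at 1.27 ug/mL.

From the compounds shown here alone, the second stereocentre is drawn the same in all three compounds, so its contribution remains open. Going by these compounds, it is also open whether the preference for S at the fluorinated carbon persists when the ethyl ester gives way to a carboxylic acid or an amide.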